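This account rests on a few compounds, and the source may have more. Where it says the series, first, only, none or still open, it means among the compounds named here.

Values in a functional assay on EC9706 cells (Homo sapiens) for antiproliferative activity, read by MTT assay, with a stated time of 48 h (on this read-out higher numbers stand for weaker inhibition and lower numbers for stronger inhibition), so far:
- compound 1 `CCCCCCCCCCCCn1cc(COC[C@@H]2OC[C@H](N)[C@@H]2O)nn1` gives 16000 nM as its value
- compound 2 `CCCCCCCCCCCCCCn1cc(COC[C@@H]2OC[C@H](N)[C@@H]2O)nn1` gives 7830 nM as its value

Compound 2 holds the lower of the two numbers. Among the measured compounds shown here, the only measured step (a 2.0-fold lower number from compound 1 to compound 2 (0.31 log units; beyond the scatter)) is a modest one on the chain, so it bears on configuration only loosely, and no measured pair tests configuration. Compound 3 `CCCCCCCCCCCCCCn1cc(COC[C@@H]2OC[C@H](N)[C@H]2O)nn1` differs from compound 2 in one way (the two compounds have the same atoms and bonds and differ only in configuration as drawn: 1 of 3 stereo elements differ; a stereocentre at a saturated ring carbon is drawn S in compound 2 and R in compound 3). A modest move toward weaker inhibition is expected in this assay (a 1.4-fold higher number from compound 2 to compound 3 (0.15 log units; within the scatter)), though its direction is uncertain. Compound 3 is estimated at 11000 nM with an expected range from 5000 nM to 30000 nM in this series.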

Compound 3, half-maximal inhibitory concentration: 6680 nM
The estimate for compound 3 lay 1.6-fold (0.22 log units) above the measured number; the measured number falls inside the stated range.
By their numbers in this assay, from the lowest: compounds 3 and 2 (each within the scatter of the next); then compound 1.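

In this assay, the change from S to R at this saturated ring carbon gives a 1.2-fold lower number from compound 2 to compound 3 (0.07 log units; within the scatter), so the two drawn configurations are not told apart at this position. The earlier compounds varied only the chain, whereas this pair gives the first reading on configuration, and its interpretation rests on one point: the fact that compounds 2 and 3 differ only in the configuration as drawn

From the compounds shown here alone, whether the same holds with the chain of compound 1, or at the other two stereocentres, remains open. Also open, going by these compounds, is what a longer chain, or a hydroxyl group in place of the amine, would do in this assay.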